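A few compounds are considered here, and "the series" means these few. Any claim that something is new, unique, unknown or untested is made for them only; others in the source may bear on it.

Measured in an in vitro ADME assay on microsomes (Homo sapiens) for pharmacokinetics; on this read-out lower numbers stand for slow clearance and higher numbers for fast clearance:
- compound 1 `O=C(NC1CC1)c1ccc(CN([C@@H]2CC(F)(F)CCNC2=O)S(=O)(=O)c2ccc(Cl)cc2)cc1`: 1.9 mL.min-1.g-1
- compound 2 `CC1(C)CCNC(=O)[C@H](N(Cc2ccc(C(=O)NC3CC3)cc2)S(=O)(=O)c2ccc(Cl)cc2)C1`: 36 mL.min-1.g-1
- compound 3 `COc1ccc(CN([C@@H]2CC(F)(F)CCNC2=O)S(=O)(=O)c2ccc(Cl)cc2)c(F)c1`: 13 mL.min-1.g-1

Of these three, compound 2 has the highest number, 36 mL.min-1.g-1. Compound 4 `CC1(C)CCNC(=O)C(N(Cc2ccc(C(=O)NC3CC3)cc2)S(=O)(=O)c2ccc(Cl)cc2)C1` has not yet been measured in this assay. It differs from compound 2 only in how it is drawn: the two compounds have the same atoms and bonds; at least one stereo element is drawn with a configuration in one of them and without one in the other: 1 of 1 stereo elements differ; a stereocentre at a saturated ring carbon is drawn R in compound 2 and without a configuration in compound 4. The same atoms and bonds are present, but the stereocentre at a saturated ring carbon carries no drawn configuration. Among the measured compounds shown here, the one measured step, a 19-fold higher number from compound 1 to compound 2 (1.28 log units; beyond the scatter), is large, but it puts 5,5-dimethyl-2-oxoazepan-3-yl in place of 5,5-difluoro-2-oxoazepan-3-yl. It therefore exchanges atoms and does not test a stereocentre. For the measured compounds named here, no measured step does, so no change beyond the scatter is expected, and no direction is predicted. The expected step is a 1.1-fold lower number from compound 2 to compound 4 (0.05 log units; within the scatter). For compound 4 the estimated value is 32 mL.min-1.g-1, with an expected range of 18 mL.min-1.g-1 to 55 mL.min-1.g-1.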

Compound 4, intrinsic clearance in microsomes: 45 mL.min-1.g-1
The estimate for compound 4 lay 1.4-fold (0.15 log units) below the measured number, and the stated range covers the measured number.
By their numbers in this assay, from the lowest: compound 1; then compound 3; then compounds 2 and 4 (each within the scatter of the next).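

In this assay, the step of a 1.3-fold higher number from compound 2 to compound 4 (0.10 log units; within the scatter) shows that leaving the configuration at this saturated ring carbon undrawn does not shift the number beyond the scatter. The large gap to the difluoro compound also holds for the undrawn form, with a 24-fold higher number from compound 1 to compound 4 (1.37 log units; beyond the scatter). This reading of the stereocentre rests on a single difference: the fact that one of compounds 2 and 4 is drawn with a defined configuration and the other without, at the place where they differ

From the compounds shown here alone, how the opposite configuration would behave on its own stays open. So does where the number would fall with a hydroxyl group in place of the two methyl groups of the 5,5-dimethyl-2-oxoazepan-3-yl group.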